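A few compounds are considered here, and "the series" means these few. Any claim that something is new, unique, unknown or untested is made for them only; others in the source may bear on it.

Working notes on the series. In a functional assay on K562 cells (Homo sapiens), read by MTT assay, with a stated time of 72 h (on this read-out higher numbers stand for weaker inhibition and lower numbers for stronger inhibition), compound 1 (`CSc1ncnc2c1c(-c1ccoc1)cn2[C@@H]1O[C@H](CO)[C@@H](O)[C@H]1O`) gives 3250 nM as a measured number. Compound 2 (`Nc1nc2c(c(-c3ccco3)cn2[C@@H]2O[C@H](CO)[C@@H](O)[C@H]2O)c(=O)[nH]1`) is reported as > 20000 nM and this entry is a limit of this assay rather than a number. Compound 2 therefore has no exact place on the scale, and any comparison has to start from the limit of > 20000 nM in this assay, at which 1 of the 2 values shown sits, and not from a measured potency.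

The next compound to be read is compound 3 (`Nc1nc2c(c(-c3cc4ccccc4o3)cn2[C@@H]2O[C@H](CO)[C@@H](O)[C@H]2O)c(=O)[nH]1`). Its change from compound 2 is 1-benzofuran-2-yl in place of furan-2-yl on an aromatic carbon and the rest of the structure stays as it is.

Within the data shown here, no measured step covers this exchange, so neither its size nor its direction can be read from the data. The working expectation is no change beyond the usual scatter of this assay and a fair chance of another limit. That expectation rests only on compound 2 with its limit of > 20000 nM as the starting point. The expected shift is a number no higher from compound 2 to compound 3 (the limit leaves the size open) and this is a weakly founded estimate. For compound 3 the estimated value is 20000 nM with an expected range from 8000 nM to 40000 nM in this read-out.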

Compound 3, half-maximal inhibitory concentration: > 20000 nM
Compound 3: no number, only a limit (the forecaster's own chance of this, stated with the estimate: 70%); the middle value sits exactly at the limit.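

No step can be read from compound 2 to compound 3, since both entries are limits and not numbers: the limit of > 20000 nM in this assay, at which 2 of the 3 values shown sit.

The compounds shown leave open how far compound 2 and compound 3 lie from that limit, and whether 1-benzofuran-2-yl in place of furan-2-yl shifts the read-out in this assay at all.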